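The source may hold more compounds than are shown below. What is called first, only, known or untested is meant among the compounds shown, and "the series" means these compounds.

Compound 1 `Cc1ccc(-c2ccc(F)cc2)n1-c1ccc(-c2nc3ccccc3s2)cc1` gives 4340 nM in a functional assay on MDA-MB-231 cells (Homo sapiens) for cytotoxicity, read by sulforhodamine B assay, with a stated time of 48 h; a lower number here means a stronger inhibitor of growth, a higher number a weaker inhibitor of growth. Compound 2 `COc1ccc(-c2ccc(C)n2-c2ccc(-c3nc4ccccc4s3)cc2)cc1` gives 3990 nM. Compound 3 `COc1ccc2nc(-c3ccc(-n4c(C)ccc4-c4ccc(F)cc4)cc3)sc2c1` gives 4060 nM.

Compound 4 `COc1ccc(-c2ccc(C)n2-c2ccc(-c3nc4ccc(OC)cc4s3)cc2)cc1` has not yet been measured. It differs from compound 3 by methoxy in place of fluoro on an aromatic carbon. The same change separates compound 1 from compound 2, (methoxy in place of fluoro on an aromatic carbon), and there it gave a 1.1-fold lower number from compound 1 to compound 2 (0.04 log units; within the scatter). Compound 3 and compound 4 carry a different core from compound 1 and compound 2; the two cores differ by methoxy in place of hydrogen on an aromatic carbon, a change that on its own gave a 1.1-fold lower number from compound 1 to compound 3 (0.03 log units; within the scatter). All three measured values lie close together. The step from compound 3 to compound 4 is expected to be a 1.1-fold lower number from compound 3 to compound 4 (0.03 log units; within the scatter), because the same change gave a 1.1-fold lower number from compound 1 to compound 2 (0.04 log units; within the scatter) on the other core. Compound 4 is therefore estimated at 3800 nM, with a likely range from 1900 nM to 7600 nM.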

Compound 4, concentration for 50% growth inhibition: 4120 nM
Estimate against measurement, compound 4: 1.1-fold (0.04 log units) below; the range from low to high includes it.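

In this assay, methoxy in place of fluoro gives a 1.0-fold higher number from compound 3 to compound 4 (0.01 log units; within the scatter), which matches the earlier step on the other core: the same change on two cores in this assay, a 1.1-fold lower number (0.04 log units; within the scatter) from compound 1 to compound 2 and a 1.0-fold higher number (0.01 log units; within the scatter) from compound 3 to compound 4, 1.1-fold (0.04 log units) apart, within the scatter of two such steps. Methoxy in place of hydrogen gives a 1.0-fold higher number from compound 2 to compound 4 (0.01 log units; within the scatter), and this also matches its earlier step: the same change on two cores in this assay, a 1.1-fold lower number (0.03 log units; within the scatter) from compound 1 to compound 3 and a 1.0-fold higher number (0.01 log units; within the scatter) from compound 2 to compound 4, 1.1-fold (0.04 log units) apart, within the scatter of two such steps. Both changes therefore look the same on the two cores, but each step is too small to read, so this does not show that a change with a larger effect would carry over in the same way.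

The compounds shown vary only between fluoro, methoxy and hydrogen, so the effect of an amine, a carboxylic acid or a longer chain at these places remains open. Also open, on these data alone, is whether any group there can move the number beyond the scatter.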